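Swapping the Ring on the Thiocarbonyl of Compound 1

This account rests on a few compounds, and the source may have more. Where it says the series, first, only, none or still open, it means among the compounds named here.

Compound 1 `N/C(=N\NC(=S)N1CCOCC1)c1ccccn1` is the strongest of the three compounds measured in a functional assay on MCF7 cells (Homo sapiens) for cytotoxicity, read by MTT assay, with a stated time of 72 h, tested at 10 uM (a higher number here means more inhibition of growth at the concentration tested, a lower number less inhibition of growth), where compound 1 gives 66.7%. Compound 2 `Cc1ccnc(/C(N)=N/NC(=S)N2CCOCC2)c1` gives 6.86%, and compound 3 `Cc1cccc(/C(N)=N/NC(=S)N2CCOCC2)n1` gives 39.1%. Both measured steps alter the same kind of place: a number 59.8 percentage points lower from compound 1 to compound 2 (beyond the scatter) and a number 27.6 percentage points lower from compound 1 to compound 3 (beyond the scatter), each putting a methyl in place of hydrogen on an aromatic carbon of the shared core. Compound 4 `N/C(=N\NC(=S)N1CCCC1)c1ccccn1` differs from compound 1 elsewhere: pyrrolidin-1-yl in place of morpholin-4-yl on a thiocarbonyl carbon. Among the measured compounds shown here, neither measured step touches the thiocarbonyl carbon, so the two steps give no direct guide to this change; they show only that each single small change made to compound 1 lowered the number beyond the scatter. With no evidence about this position, a modest downward step in this assay is expected, though a result within the scatter of compound 1 cannot be ruled out. For compound 4 the estimate in this assay is 52%, with a range from 22% to 78%, an expected step of a number 14.7 percentage points lower from compound 1 to compound 4 (beyond the scatter).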

Compound 4, percent growth inhibition at one concentration: 51.7%
Compound 4: middle estimate off by 0.3 percentage points, on the high side; measured number inside the range.
By their numbers in this assay, from the lowest: compound 2; then compound 3; then compound 4; then compound 1.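

Among the compounds shown here, this is the first reading at the thiocarbonyl carbon: in this assay, pyrrolidin-1-yl in place of morpholin-4-yl gives a number 15 percentage points lower from compound 1 to compound 4 (beyond the scatter), a modest step, so the position tolerates this exchange with some loss of growth inhibition. The exchange removes the ring oxygen, with the one hydrogen-bond acceptor counted on the group, and also turns a six-membered ring into a five-membered one, so this single step cannot separate those two differences. Nothing measured here explains the drop.

Still open, as far as these compounds go, is whether piperidin-1-yl, a six-membered ring without the oxygen, would sit closer to compound 1 or to compound 4, which would begin to pull ring size and the oxygen apart. An open-chain group such as dimethylamino on the thiocarbonyl carbon would show whether a ring is needed there at all.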